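The source may report more compounds than this note shows. Statements on the series, on what has been measured and on what is new or still open speak of the compounds shown alone.

Compound 1 `c1cc([C@H]2CC[C@]3(CC2)OOC2(O3)C3CC4CC(C3)CC2C4)ccc1OCCCNC1CCOCC1` gives 10 mL.min-1.g-1 in an ADME assay on microsomes from liver (Homo sapiens) for metabolic stability, read by LC-MS, tested at 1 uM; on this read-out higher numbers stand for fast clearance and lower numbers for slow clearance.
Compound 2 `N[C@H]1CC[C@H](Oc2ccc([C@H]3CC[C@]4(CC3)OOC3(O4)C4CC5CC(C4)CC3C5)cc2)CC1` gives only a limit of the assay, < 7 mL.min-1.g-1.
Compound 3 `NCCOc1ccc([C@H]2CC[C@]3(CC2)OOC2(O3)C3CC4CC(C3)CC2C4)cc1` also gives only a limit, < 7 mL.min-1.g-1.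

Among the measured compounds shown here, compound 1 thus stands as the only measured number among the three; the other two sit at the limit of < 7 mL.min-1.g-1 in this assay, at which 2 of the 3 values shown sit. The step of an at least 1.4-fold lower number from compound 1 to compound 2 (0.15 log units; that floor lies within the scatter) and the step of an at least 1.4-fold lower number from compound 1 to compound 3 (0.15 log units; that floor lies within the scatter) both run from compound 1 toward that limit, while the step that the two limits leave unreadable from compound 2 to compound 3. Compound 4 `OC1(COc2ccc([C@H]3CC[C@]4(CC3)OOC3(O4)C4CC5CC(C4)CC3C5)cc2)CCNCC1` differs from compound 1 by 4-hydroxypiperidin-4-yl in place of 2-((oxan-4-yl)amino)ethyl on a saturated chain carbon bound to an oxygen on an aromatic ring. Since both measured changes at that chain gave a number no higher than compound 1, a downward step or none beyond the scatter is expected here. Compound 4 is estimated at 7 mL.min-1.g-1, between 4 mL.min-1.g-1 and 14 mL.min-1.g-1, which is the expected step of a 1.4-fold lower number from compound 1 to compound 4 (0.15 log units; within the scatter).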

Compound 4, intrinsic clearance in microsomes: 16 mL.min-1.g-1
The estimate for compound 4 lay 2.3-fold (0.36 log units) below the measured number; measured number above the stated range.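

At this position a change can raise the clearance number. The (4-hydroxypiperidin-4-yl)methyl group in place of 4-aminocyclohexyl gives an at least 2.2-fold higher number from compound 2 to compound 4 (0.35 log units; beyond the scatter), and 4-hydroxypiperidin-4-yl in place of aminomethyl gives an at least 2.2-fold higher number from compound 3 to compound 4 (0.35 log units; beyond the scatter), whereas 4-hydroxypiperidin-4-yl in place of 2-((oxan-4-yl)amino)ethyl gives only a 1.6-fold higher number from compound 1 to compound 4 (0.20 log units; within the scatter), which leaves that pair unordered. The two larger steps are floors, set by a limit of the assay: the limit of < 7 mL.min-1.g-1 in this assay, at which 2 of the 4 values shown sit.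

The compounds shown leave open whether the hydroxyl group or the piperidine ring goes with the higher number. A piperidin-4-ylmethyl group without the hydroxyl would separate the two.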